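Cyclopentyl for cyclohexyl on compound 2

A few compounds are considered here, and "the series" means these few. Any claim that something is new, unique, unknown or untested is made for them only; others in the source may bear on it.

Measured in an ADME assay on Huh-7 cells (Homo sapiens) for cytotoxicity, read by MTT assay; a higher number here means that more compound is tolerated, a lower number that less compound is tolerated:
compound 1 (`Cn1cnc(=O)c2cc(Oc3ncccc3C(F)(F)F)ccc21`) gives > 10 uM, a limit
compound 2 (`O=c1ncn(CC2CCCCC2)c2ccc(Oc3ncccc3C(F)(F)F)cc12`) gives > 10 uM, a limit

Neither entry is a true number, and the record so far comes down to the limit of > 10 uM in this assay, at which 2 of the 2 values shown sit. In this assay compound 2 therefore stands only at a limit of > 10 uM.

Compound 3 (`O=c1ncn(CC2CCCC2)c2ccc(Oc3ncccc3C(F)(F)F)cc12`) differs from compound 2 in one place: cyclopentyl in place of cyclohexyl on a saturated chain carbon bound to an aromatic nitrogen. Going by the values given here, the only measured step that bears on this change is a step that the two limits leave unreadable from compound 1 to compound 2, and it gives no size to build on. No step beyond the usual scatter is therefore expected in this assay, in either direction, and another limit is the likeliest report. The expected change is a step that the limit leaves unreadable from compound 2 to compound 3. The estimate for compound 3 is 15 uM, with an expected range from 10 uM to 40 uM.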

Compound 3, half-maximal toxic concentration: > 10 uM
Compound 3 ended at the assay's limit; the forecaster's own chance of this, stated with the estimate: 85%; the middle value does not contradict the limit.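

Going by these compounds alone, compound 1, compound 2 and compound 3 each give only a limit, not a true number, in this assay, so no step among them can be read: the limit of > 10 uM in this assay, at which 3 of the 3 values shown sit. The compounds shown leave open whether cyclopentyl, cyclohexyl and hydrogen differ in how much compound is tolerated.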